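This account rests on a few compounds, and the source may have more. Where it says the series, first, only, none or still open, it means among the compounds named here.

The measured compounds and their values:

compound 1, `COc1ccc(C(=O)c2ccc3c(ccn3S(=O)(=O)c3cccc(/C=C/C(=O)NO)c3)c2)cc1`, gives 812 nM;
compound 2, `COc1ccc(C(=O)c2ccc3c(ccn3S(=O)(=O)c3ccc(/C=C/C(=O)NO)cc3)c2)cc1`, gives 10000 nM;
compound 3, `COc1ccc(C(=O)c2ccc3c(ccn3Cc3ccc(C(=O)NO)cc3)c2)cc1OC`, gives 756 nM.

All three numbers come from an assay on isolated protein for inhibition of histone deacetylase 8 (Homo sapiens); on this read-out lower numbers stand for stronger inhibition and higher numbers for weaker inhibition. Compound 1 holds the second highest number of the three. Its nearest neighbour is compound 3, whose number lies within the usual scatter of compound 1, so the two cannot be told apart. Compound 2 stands far away: its number is well beyond the scatter and marks clearly weaker inhibition than compound 1.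

The next compound, compound 4, `COc1cc(C(=O)c2ccc3c(ccn3S(=O)(=O)c3cccc(/C=C/C(=O)NO)c3)c2)cc(OC)c1OC`, keeps everything of compound 1 except one group: 3,4,5-trimethoxyphenyl in place of 4-methoxyphenyl on a carbonyl carbon. Within the data shown here, no pair of measured compounds differs only in this group, so the data give no direct guide to the size of this step. The expectation is a small step in this assay, if any, not clearly beyond the scatter, with no firm direction: the estimated step is a 1.1-fold higher number from compound 1 to compound 4 (0.04 log units; within the scatter). For compound 4 the estimated value in this assay is 900 nM, within a range from 300 nM to 3000 nM.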

Compound 4, half-maximal inhibitory concentration: 1260 nM
Estimate against measurement, compound 4: 1.4-fold (0.15 log units) below, and the stated range covers the measured number.
By their numbers in this assay, from the lowest: compounds 3, 1 and 4 (each within the scatter of the next); then compound 2.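

Read in this assay, swapping 4-methoxyphenyl for 3,4,5-trimethoxyphenyl on a carbonyl carbon gives a 1.6-fold higher number from compound 1 to compound 4 (0.19 log units; within the scatter), the first direct reading of a change at this place. On the core of compound 1, then, a group with more heavy atoms and more hydrogen-bond acceptors leaves the number indistinguishable from the original, so this one swap shows no clear effect on inhibition. Nothing available explains why the two compounds read alike.

On these data alone, whether the same swap would behave the same way with the sulfonyl-linked side chain of compound 2, or of compound 3, remains open. Also open, as far as these compounds go, is how a group of a different kind on that carbonyl carbon, such as a pyridine ring, an aminophenyl group or a simple methyl, would read in this assay.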